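Pyrazole dicarboxylates on DU-145 cells: methyl versus ethyl esters

A few compounds are considered here, and "the series" means these few. Any claim that something is new, unique, unknown or untested is made for them only; others in the source may bear on it.

Measured compounds:
compound 1, `CCOC(=O)c1c(-c2cc3ccccc3oc2=O)nn(-c2cccc(F)c2)c1C(=O)OCC`, 32000 nM
compound 2, `COC(=O)c1c(-c2cc3ccccc3oc2=O)nn(-c2cccc(F)c2)c1C(=O)OC`, 37000 nM
compound 3, `CCOC(=O)c1c(-c2cc3ccccc3oc2=O)nn(-c2ccc(Br)cc2)c1C(=O)OCC`, 61000 nM

Of the compounds shown here, three built on a shared core have been tested in a functional assay on DU-145 cells (Homo sapiens) for cytotoxicity, read by MTT assay, with a stated time of 48 h; on this read-out lower numbers stand for stronger inhibition and higher numbers for weaker inhibition. Compound 1 `CCOC(=O)c1c(-c2cc3ccccc3oc2=O)nn(-c2cccc(F)c2)c1C(=O)OCC` gives 32000 nM. Compound 2 `COC(=O)c1c(-c2cc3ccccc3oc2=O)nn(-c2cccc(F)c2)c1C(=O)OC`, in this assay, gives 37000 nM. Compound 3 `CCOC(=O)c1c(-c2cc3ccccc3oc2=O)nn(-c2ccc(Br)cc2)c1C(=O)OCC` gives 61000 nM. The difference between the cores of compound 1 and compound 2 is not broken down here.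

Compound 1 and compound 3 differ in one place, (4-bromophenyl in place of 3-fluorophenyl on an aromatic nitrogen), and this change made a 1.9-fold higher number from compound 1 to compound 3 (0.28 log units; within the scatter). The values of compound 1 and compound 2 lie within the scatter of each other, as do those of compound 2 and compound 3.

Compound 4 `COC(=O)c1c(-c2cc3ccccc3oc2=O)nn(-c2ccc(Br)cc2)c1C(=O)OC` has not yet been measured. It stands to compound 2 as compound 3 stands to compound 1: 4-bromophenyl in place of 3-fluorophenyl on an aromatic nitrogen. The two changes are the same kind of change rather than the same one, since in compound 2 the place is next to the ring atom that bears a methoxycarbonyl group, while in compound 1 it is next to the ring atom that bears an ethoxycarbonyl group. In this assay compound 4 is expected to show a 1.8-fold higher number from compound 2 to compound 4 (0.24 log units; within the scatter), an expectation that rests on the step of a 1.9-fold higher number from compound 1 to compound 3 (0.28 log units; within the scatter) and on the value of compound 2, 37000 nM. Compound 4 is therefore estimated at 65000 nM, with a range from 30000 nM to 140000 nM.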

Compound 4, half-maximal inhibitory concentration: 93000 nM
Beside the measured number, compound 4's estimate is 1.4-fold (0.16 log units) below it, and the stated range covers the measured number.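

In this assay, 4-bromophenyl in place of 3-fluorophenyl on the aromatic nitrogen gave a 2.5-fold higher number from compound 2 to compound 4 (0.40 log units; beyond the scatter), a modest step on the core that carries the methoxycarbonyl groups. Going by these compounds alone, the same change on the core that carries the ethoxycarbonyl groups gave a step that cannot be told apart from this one, so within these two pairs the change carries over from one core to the other with no measurable difference in size: the same change on two cores in this assay, a 1.9-fold higher number (0.28 log units; within the scatter) from compound 1 to compound 3 and a 2.5-fold higher number (0.40 log units; beyond the scatter) from compound 2 to compound 4, 1.3-fold (0.12 log units) apart, within the scatter of two such steps This does not establish a general rule for the series, as it rests on only two cores and one exchange of groups, only one of the two steps lies beyond the scatter, and the exchange alters both the halogen and its place on the phenyl ring, so the two cannot be separated.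

The compounds shown leave open how a plain phenyl group, or a phenyl group carrying an amine, would read on the aromatic nitrogen. They also leave open whether the step would hold if the esters gave way to a carboxylic acid or to a longer chain such as a butyl ester.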